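The source may hold more compounds than are shown below. What is called first, only, known or untested is meant among the compounds shown, and "the series" means these compounds.

Compound 3 `CCCOC(=O)c1cccc(-c2cc(C(=O)Nc3ccncc3F)ccc2CN)c1` carries a propyl ester on the shared core; in an assay on isolated protein for inhibition of Rho-associated protein kinase 2 (Homo sapiens), read by radiometric assay (on this read-out lower numbers stand for stronger inhibition and higher numbers for weaker inhibition), compound 3 gives 5.1 nM. Its two neighbours vary only the ester group: compound 1 `NCc1ccc(C(=O)Nc2ccncc2F)cc1-c1cccc(C(=O)OCC2CC2)c1` gives 2.7 nM in this assay, and compound 2 `NCc1ccc(C(=O)Nc2ccncc2F)cc1-c1cccc(C(=O)OCC2CCCO2)c1` gives 2.5 nM. The step of a 1.9-fold higher number from compound 1 to compound 3 (0.28 log units; within the scatter) stays within the scatter, whereas a 2.0-fold higher number from compound 2 to compound 3 (0.31 log units; beyond the scatter) is a modest change beyond it, so compound 3 sits at the weaker edge of the three. Compound 4 `COC(=O)c1cccc(-c2cc(C(=O)Nc3ccncc3F)ccc2CN)c1` shortens the ester further: hydrogen in place of ethyl on a saturated chain carbon bound to an oxygen next to a carbonyl group. Both earlier steps at this position were small, so only a small shift toward a higher number, or none beyond the scatter, is expected for a 1.3-fold higher number from compound 3 to compound 4 (0.11 log units; within the scatter). Compound 4 is therefore estimated at 6.5 nM, with a likely range from 2.5 nM to 16 nM.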

Compound 4, half-maximal inhibitory concentration: 7.8 nM
The estimate for compound 4 lay 1.2-fold (0.08 log units) below the measured number; low and high end bracket the measured number.
By their numbers in this assay, from the lowest: compounds 2, 1, 3 and 4 (each within the scatter of the next, the first and the last beyond it).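

The step of a 1.5-fold higher number from compound 3 to compound 4 (0.18 log units; within the scatter) shows that cutting propyl back to methyl does not by itself move the number beyond the scatter. Compound 4 is nevertheless the first of these esters to stand clear of both ring-bearing esters, with a 2.9-fold higher number from compound 1 to compound 4 (0.46 log units; beyond the scatter) and a 3.1-fold higher number from compound 2 to compound 4 (0.49 log units; beyond the scatter) as modest steps, whereas compound 3 stood clear only of compound 2. No evidence is available that bears on this result. The compounds shown leave open how a carboxylic acid, a primary amide or a longer chain such as butyl would read at this position.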